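The source may report more compounds than this note shows. Statements on the series, on what has been measured and on what is new or still open speak of the compounds shown alone.

Compound 1, `N#Cc1cccc(-c2ccc(CN(CCCN3CCCC3)C(=O)Nc3cc(Cl)cc(Cl)c3)cc2)c1`: 48 nM in a functional assay for antagonist activity at melanin-concentrating hormone receptor 1 (Homo sapiens); a lower number here means a stronger inhibitor, a higher number a weaker inhibitor
Compound 2, `N#Cc1cccc(-c2ccc(CN(CC(=O)Nc3cc(Cl)cc(Cl)c3)C(=O)CN3CC[C@@H](O)C3)cc2)c1`: 61 nM
Compound 3, `C[C@H](c1ccc(-c2cccc(C#N)c2)cc1)N(CC(=O)Nc1cc(Cl)cc(Cl)c1)C(=O)CCN1CC[C@H](O)C1`: 23 nM

Among these three, compound 3 gives the lowest number in this assay; its gaps to compound 1 and to compound 2 both lie beyond the usual scatter, so compound 3 is the strongest of the three as measured. Compound 4, `C[C@@H](c1ccc(-c2cccc(C#N)c2)cc1)N(CC(=O)Nc1cc(Cl)cc(Cl)c1)C(=O)CCN1CC[C@H](O)C1`, has not yet been measured. (the two compounds have the same atoms and bonds and differ only in configuration as drawn: 1 of 2 stereo elements differ; a stereocentre at a saturated chain carbon is drawn R in compound 3 and S in compound 4). Among the measured compounds shown here, no measured pair here shows what flipping that centre does, so the size of the step is uncertain. A change of configuration alone can leave potency unchanged or weaken it markedly, so the step of a 3.0-fold higher number from compound 3 to compound 4 (0.48 log units; beyond the scatter) is expected to run towards a higher number, with a wide range. Compound 4 is estimated at 70 nM, between 20 nM and 400 nM.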

Compound 4, inhibition constant: 18 nM
The estimate for compound 4 lay 3.9-fold (0.59 log units) above the measured number; the whole stated range lies above it.
By their numbers in this assay, from the lowest: compounds 4 and 3 (each within the scatter of the next); then compounds 1 and 2 (each within the scatter of the next).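

In this assay, turning the stereocentre at the saturated chain carbon from R to S gives a 1.3-fold lower number from compound 3 to compound 4 (0.11 log units; within the scatter). Among the compounds shown here, both configurations are therefore tolerated at this position, which no earlier compound could show. This pair tests that centre alone, because nothing else changes: the fact that compounds 3 and 4 differ only in the configuration as drawn.

From the compounds shown here alone, it remains open whether an ethyl group on this carbon, in place of the methyl, would separate the two configurations. The effect of inverting the second stereocentre, which compound 3 and compound 4 share, is also unknown.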